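Adding a (diethylamino)methyl chain to a urea-bearing benzothiazole

This account rests on a few compounds, and the source may have more. Where it says the series, first, only, none or still open, it means among the compounds named here.

Compound 1: `CNC(=O)Nc1nc2ccc(-c3cnc(OC)c(NS(=O)(=O)c4ccc(F)cc4)c3)cc2s1`, 1190 nM
Compound 2: `O=S(=O)(Nc1cc(-c2ccc3nc(NC4CC4)sc3c2)cnc1Cl)c1ccc(F)cc1`, "not determined" (no result reported)
Compound 3: `CCN(CC)CCNC(=O)Nc1nc2ccc(-c3cnc(Cl)c(NS(=O)(=O)c4ccc(F)cc4)c3)cc2s1`, 710 nM

Three compounds share one core, and two of them have a number in a functional assay on MCF7 cells (Homo sapiens) for antiproliferative activity, read by MTT assay, with a stated time of 72 h; a lower number here means a stronger inhibitor, a higher number a weaker inhibitor. Compound 1 gives 1190 nM, the higher of the two numbers. Compound 3 gives 710 nM, and the gap between these two lies within the scatter, so neither can be called the stronger. In this assay compound 2 gives "not determined" (no result reported). Among the measured compounds shown here, compound 3 differs from compound 1 in two places at once, so no single step connects them.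

Compound 4 is `CCN(CC)CCNC(=O)Nc1nc2ccc(-c3cnc(OC)c(NS(=O)(=O)c4ccc(F)cc4)c3)cc2s1`. It differs from compound 1 in one place only: (diethylamino)methyl in place of hydrogen on a saturated chain carbon bound to an amide-type nitrogen. The same chain is already present in compound 3, which differs from compound 4 only elsewhere. Since compound 3 gives 710 nM and compound 1 gives 1190 nM, nothing here points to a large move in either direction.

Compound 4 is therefore expected to sit close to both, with an estimated step of a 1.4-fold lower number from compound 1 to compound 4 (0.15 log units; within the scatter) that stays within the scatter. The estimate for compound 4 is 850 nM, with a range from 350 nM to 2000 nM.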

Compound 4, half-maximal inhibitory concentration: 320 nM
Beside the measured number, compound 4's estimate is 2.7-fold (0.42 log units) above it; the whole stated range lies above it.
By their numbers in this assay, from the lowest: compound 4; then compounds 3 and 1 (each within the scatter of the next).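

In this assay, among the compounds shown here, the earlier compounds offered no single change to read, and compound 4 now supplies two. With methoxy held the same, (diethylamino)methyl in place of hydrogen on a saturated chain carbon bound to an amide-type nitrogen gives a 3.7-fold lower number from compound 1 to compound 4 (0.57 log units; beyond the scatter), so this chain can change the number by more than the usual scatter; with that chain held the same, methoxy in place of chloro on an aromatic carbon gives a 2.2-fold lower number from compound 3 to compound 4 (0.35 log units; beyond the scatter), so the aromatic carbon also matters. No measurement shown here accounts for either step.

From the compounds shown here alone, each step rests on a single pair, so it remains open whether another chain, such as 3-(diethylamino)propyl, or a chain carrying a morpholine in place of the diethylamino group, would give a similar number. Going by these compounds, it is also open whether other groups on the same aromatic carbon, such as fluoro or ethoxy, would give a lower or higher number than methoxy and chloro, and whether the chain step would be the same size with chloro there.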